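A few compounds are considered here, and "the series" means these few. Any claim that something is new, unique, unknown or untested is made for them only; others in the source may bear on it.

Working notes on the series in an ADME assay on HEK-293T cells (Homo sapiens) for inhibition, read by CCK-8 assay, with a stated time of 48 h, tested at 20 uM; on this read-out higher numbers stand for more inhibition of growth at the one concentration tested and lower numbers for less inhibition of growth. Compound 1 `Cc1ccc(S(=O)(=O)Oc2ccccc2/C=C(\C#N)C(=O)Nc2nnc(Cc3cccc4ccccc34)s2)cc1` gives 23% and compound 2 `N#C/C(=C\c1ccccc1OS(=O)(=O)c1ccc([N+](=O)[O-])cc1)C(=O)Nc1nnc(Cc2cccc3ccccc23)s1` gives 25%. Compound 2 therefore stands level with compound 1 within the scatter, and the two cannot be ranked. Compound 3 `N#C/C(=C\c1ccccc1OS(=O)(=O)c1ccccc1[N+](=O)[O-])C(=O)Nc1nnc(Cc2cccc3ccccc23)s1` is not yet measured and has the same atoms as compound 2, joined differently: 2-nitrophenyl in place of 4-nitrophenyl on a sulfonyl sulfur. In words, 2-nitrophenyl stands in place of 4-nitrophenyl on a sulfonyl sulfur, and the rest of the structure is unchanged.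

Among the compounds with values here, no measured pair shows this exact exchange. Within the data shown here, the only measured step that bears on it is a number 2 percentage points higher from compound 1 to compound 2 (within the scatter), with nitro in place of methyl on an aromatic carbon. That step concerns the same aryl group on the sulfonyl sulfur, but it is a different substitution, so it is only indirect evidence. On that basis, no change beyond the scatter is expected in this assay, and no direction can be favoured. The expected step is no change at the digits printed from compound 2 to compound 3 (within the scatter). For compound 3 the estimate is 25%, with an expected range of 13% to 38%.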

Compound 3, percent growth inhibition at one concentration: "not toxic" (no number reported)
No number was reported for compound 3, and the estimate cannot be compared.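

In this assay, within the data shown here, compound 3 carries a verbal entry without a number, so no step from compound 2 to compound 3 can be read. No supporting measurement bears on this result. The compounds shown leave open whether 2-nitrophenyl in place of 4-nitrophenyl on a sulfonyl sulfur alters growth inhibition at all, and in which direction.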